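The source may hold more compounds than are shown below. What is called first, only, known or untested is meant among the compounds shown, and "the series" means these compounds.

In an assay on microsomes for inhibition of Amine oxidase [flavin-containing] A (Homo sapiens), read by fluorescence and spectrophotometry, with a stated time of 20 min (a lower number here means a stronger inhibitor, a higher number a weaker inhibitor), compound 1 `O=c1ccoc2ccc(OCc3cccc(Cl)c3)cc12` gives 424 nM.
In this assay compound 2 `O=c1ccoc2ccc(OCc3cccc(Br)c3)cc12` gives 386 nM.
In this assay compound 3 `O=c1ccoc2ccc(OCc3cccc(F)c3)cc12` gives 1230 nM.

Compound 3 has the highest number of the three: a 2.9-fold higher number from compound 1 to compound 3 (0.46 log units; beyond the scatter) and a 3.2-fold higher number from compound 2 to compound 3 (0.50 log units; beyond the scatter), whereas a 1.1-fold lower number from compound 1 to compound 2 (0.04 log units; within the scatter). Compound 4 `Cc1cccc(COc2ccc3occc(=O)c3c2)c1` differs from compound 3 by methyl in place of fluoro on an aromatic carbon. Among the measured compounds shown here, no measured step involves a methyl, so only the two halogen swaps bear on this change, and both show that replacing fluoro with a larger group at this position lowered the number to a modest degree. Compound 4 is therefore expected to show a modestly lower number than compound 3, a 2.2-fold lower number from compound 3 to compound 4 (0.35 log units; beyond the scatter). The estimate for compound 4 in this assay is 550 nM, within a range of 250 nM to 1400 nM.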

Compound 4, half-maximal inhibitory concentration: 1130 nM
Compound 4: middle estimate off by 2.1-fold (0.31 log units), on the low side; low and high end bracket the measured number.
By their numbers in this assay, from the lowest: compounds 2 and 1 (each within the scatter of the next); then compounds 4 and 3 (each within the scatter of the next).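

In this assay, methyl in place of fluoro on this aromatic carbon leaves the number within the scatter, at a 1.1-fold lower number from compound 3 to compound 4 (0.04 log units; within the scatter). Methyl instead sits apart from bromo and chloro, with a 2.9-fold higher number from compound 2 to compound 4 (0.47 log units; beyond the scatter) and a 2.7-fold higher number from compound 1 to compound 4 (0.43 log units; beyond the scatter), so leaving fluoro does not by itself lower the number: bromo and chloro do, whereas methyl does not. No measurement available here explains this grouping. The compounds shown leave open where a methoxy, a hydroxyl or an amine at this place would fall relative to these two pairs.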